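The compounds below may be only part of what the source reports. "The series", "measured", "known", "first", "only" and "open" are said of these compounds alone.

Measured compounds:
- compound 1, `Fc1ccccc1-c1cn2ccnc2c(-c2ccc3ncn(C4CCCCC4)c3c2)n1`: 32.6%
- compound 2, `c1csc(-c2cn3ccnc3c(-c3ccc4ncn(C5CCCCC5)c4c3)n2)c1`: 49.1%
- compound 3, `CCc1ccc(-c2cn3ccnc3c(-c3ccc4ncn(Cc5ccccc5)c4c3)n2)cc1`: 50.4%

All three were tested in a functional assay on PC-3 cells (Homo sapiens) for inhibition, read by sulforhodamine B assay, with a stated time of 48 h, tested at 10 uM; on this read-out higher numbers stand for more inhibition at the one concentration tested (going by the name of the read-out) and lower numbers for less inhibition. Compound 3 and compound 2 give numbers that lie within the scatter of each other, so nothing separates them; the number for compound 3 exceeds that for compound 1 by a gap beyond the scatter.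

Compound 4, `Cc1cccc(-c2cn3ccnc3c(-c3ccc4ncn(Cc5ccccc5)c4c3)n2)c1`, differs from compound 3 in one place: 3-methylphenyl in place of 4-ethylphenyl on an aromatic carbon. For the measured compounds named here, the only measured single step, a number 16.5 percentage points higher from compound 1 to compound 2 (beyond the scatter), concerns a different exchange, a thiophen-2-yl for a 2-fluorophenyl, and so tells little about swapping one hydrocarbon-substituted phenyl for another. Compound 2 and compound 3 differ in two places at once, so their values cannot be read as a single step. Nothing measured points to a large move, and the change from a 4-ethylphenyl to a 3-methylphenyl keeps ring, donors and acceptors unchanged.

Compound 4 is therefore expected to give about 48% in this assay, with a likely range from 30% to 64%, and the expected step of a number 2.4 percentage points lower from compound 3 to compound 4 (within the scatter) stays within the scatter.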

Compound 4, a percentage reported as inhibition, at one concentration (the size of the read-out at that concentration, not a potency): 24.8%
Compound 4: the middle estimate sits 23.2 percentage points above what was measured; the measured number lies below the stated range.
By their numbers in this assay, from the lowest: compounds 4 and 1 (each within the scatter of the next); then compounds 2 and 3 (each within the scatter of the next).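

This position on the shared core is sensitive to small changes: in this assay, 3-methylphenyl in place of 4-ethylphenyl gives a number 25.6 percentage points lower from compound 3 to compound 4 (beyond the scatter). The earlier step swapped one ring for a different kind of ring, whereas here both groups are six-membered carbon rings with no hydrogen-bond donors or acceptors and no net charge, so those shared features do not ensure a similar result. No available evidence explains this step.

The compounds shown leave open whether the difference follows from exchanging ethyl for methyl or from where that group sits on the phenyl ring, since both change together here. A 4-methylphenyl or a 3-ethylphenyl would separate these two changes, and an aminophenyl would test a group of another kind at this position.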